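A few compounds are considered here, and "the series" means these few. Any claim that something is new, unique, unknown or untested is made for them only; others in the source may bear on it.

Compound 1 `CS(=O)(=O)Oc1c(C(=O)NCc2ccc(F)cc2)nc(Br)c2cccnc12` and compound 2 `N[C@H]1CC[C@H](Nc2c(C(=O)NCc3ccco3)nc(Br)c3cccnc23)CC1` share one core and differ in their side groups. In a functional assay on MDA-MB-435 cells (Homo sapiens) for cytotoxicity, read by MTT assay, with a stated time of 72 h (on this read-out lower numbers stand for stronger inhibition and higher numbers for weaker inhibition), compound 1 gives only the assay limit of > 20000 nM, not a number. Compound 2 in this assay likewise reaches only a limit of > 10000 nM. So compound 2 stands at a limit, as does the other value shown (the limit of > 10000 nM in this assay, at which 1 of the 2 values shown sits). Compound 3 `N[C@H]1CC[C@H](Nc2c(C(=O)NCc3ccccc3)nc(Br)c3cccnc23)CC1` is not yet measured; it carries phenyl in place of furan-2-yl on a saturated chain carbon bound to an amide-type nitrogen. Within the data shown here, with no measured step to lean on, the expected step is a step that the limit leaves unreadable from compound 2 to compound 3, nothing beyond the usual scatter. Compound 3 is therefore estimated at 15000 nM, within 5000 nM to 50000 nM, most likely again as a limit.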

Compound 3, half-maximal inhibitory concentration: 7000 nM
The estimate for compound 3 lay 2.1-fold (0.33 log units) above the measured number, and the stated range covers the measured number.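

In this assay compound 3 gives an actual number, 7000 nM, the first of the compounds shown to do so. Phenyl in place of furan-2-yl on a saturated chain carbon bound to an amide-type nitrogen gives an at least 1.4-fold lower number from compound 2 to compound 3 (0.15 log units; that floor lies within the scatter), so this place can hold a phenyl group and still give a readable value. Compound 2 sits at a limit, so this step is only a floor and its true size stays unknown: the limit of > 10000 nM in this assay, at which 1 of the 3 values shown sits.

From the compounds shown here alone, how a cyclohexyl ring or a longer chain such as 2-phenylethyl would read at this place remains open.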